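The source may hold more compounds than are shown below. What is called first, only, known or untested is meant among the compounds shown, and "the series" means these compounds.

Measured so far in a functional assay on CHO-K1 cells for antagonist activity at adenosine receptor A1 (Homo sapiens), read by a beta-galactosidase reporter and cAMP accumulation, with stated times of 15 min and 6 h; on this read-out lower numbers stand for stronger inhibition and higher numbers for weaker inhibition:

Compound 1 `Cc1ccc(-c2nc(N)c3ccsc3n2)o1` gives 493 nM.
Compound 2 `Cc1ccc(-c2nc(N)c3cc(Cc4ccccc4F)sc3n2)o1` gives < 16 nM, which is a limit of the assay and not a number.
Compound 3 `CC(C)c1ccc(-c2nc(N)c3cc(Cc4ccccc4)sc3n2)o1` gives 283 nM.

Where compound 3 stands: of the two numbers shown it is the lower, and the nearest, compound 1, differs from it by a gap that lies within the usual scatter, so no order is read into the pair. Compound 2 sits at the limit of < 16 nM in this assay, at which 1 of the 3 values shown sits, and is set aside from comparisons of size.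

For the measured compounds named here, the only measured step in this assay is an at least 30-fold lower number from compound 1 to compound 2 (1.48 log units; beyond the scatter), a change at the 2-fluorobenzyl position on the thiophene side of the shared core. It does not touch the position altered here.

Compound 4 `Nc1nc(C2CCCO2)nc2sc(Cc3ccccc3)cc12` differs from compound 3 by oxolan-2-yl in place of 5-isopropylfuran-2-yl on an aromatic carbon. Going by the values given here, no measured step in this assay concerns this position, and nothing among the measured compounds separates the aromatic furan from a saturated ring at it, nor the isopropyl from hydrogen. The expectation is therefore weakly founded: for compound 4 the number is expected to rise, with the step of a 3.2-fold higher number from compound 3 to compound 4 (0.50 log units; beyond the scatter), giving an estimated 900 nM, range 200 nM to 4000 nM.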

Compound 4, inhibition constant: 2950 nM
For compound 4 the middle estimate is 3.3-fold (0.52 log units) below the measured one, and the stated range covers the measured number.
By their numbers in this assay, from the lowest: compounds 3 and 1 (each within the scatter of the next); then compound 4. At a limit, below all of these: compound 2.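

In this assay the position between two ring nitrogen atoms now has its first measured step, with a 10-fold higher number from compound 3 to compound 4 (1.02 log units; beyond the scatter) when oxolan-2-yl enters in place of 5-isopropylfuran-2-yl. The rest of the structure is the same in both compounds, so the whole step belongs to this single exchange, and the number in this assay clearly depends on the group held at this position. The exchange is not a single-feature change, however: a five-membered aromatic ring gives way to a five-membered non-aromatic ring, and the isopropyl goes with it, leaving a group with fewer heavy atoms.

Still open, on these data alone, is how the step divides between the loss of the aromatic ring and the loss of the isopropyl; a furan-2-yl with no substituent and an oxolan-2-yl carrying an isopropyl would separate the two, while an amine or a carboxylic acid on the ring would probe groups of another kind. As for the cause of the step, nothing measured here speaks to it.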